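The compounds below may be only part of what the source reports. "The series", "measured", "known", "first", "only" and "open" are said of these compounds alone.

Compound 1 `C=CCn1c(=O)/c(=C\c2cccc(F)c2)[nH]c(=O)/c1=C\c1ccccc1OC`: 4100 nM
Compound 2 `COc1ccccc1/C=c1\c(=O)[nH]/c(=C/c2ccccc2Cl)c(=O)n1C`: 110 nM

In a functional assay on K562 cells (Homo sapiens) for cytotoxicity, read by CCK-8 assay, with a stated time of 72 h (a lower number here means a stronger inhibitor, a higher number a weaker inhibitor), compound 1 gives 4100 nM, the higher of the two numbers. Compound 2 gives 110 nM, a gap beyond the scatter. Compound 3 `C=CCn1c(=O)/c(=C\c2ccccc2OC)[nH]c(=O)/c1=C\c1ccccc1OC` comes from compound 1 by a single change: 2-methoxyphenyl in place of 3-fluorophenyl on a double-bonded chain carbon bound to an aromatic carbon. Among the measured compounds shown here, no two measured compounds differ in only one place, so the data do not show how this change acts on its own. Compound 2 also carries a 2-methoxyphenyl group, yet it differs from compound 1 in further places. For compound 3 a modest move to a lower number in this assay is expected, a 2.3-fold lower number from compound 1 to compound 3 (0.36 log units; beyond the scatter). The estimate for compound 3 is 1800 nM, within 450 nM to 7000 nM.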

Compound 3, half-maximal inhibitory concentration: 7400 nM
The estimate for compound 3 lay 4.1-fold (0.61 log units) below the measured number; the whole stated range lies below it.
By their numbers in this assay, from the lowest: compound 2; then compounds 1 and 3 (each within the scatter of the next).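

Among the compounds shown here, the swap to 2-methoxyphenyl in place of 3-fluorophenyl on a double-bonded chain carbon bound to an aromatic carbon gives a 1.8-fold higher number from compound 1 to compound 3 (0.26 log units; within the scatter) in this assay and is the first change seen on its own. At this position the two groups cannot be told apart by this measurement, even though 2-methoxyphenyl carries a hydrogen-bond acceptor and 3-fluorophenyl carries none. No measurement at hand explains this result.

Going by these compounds, whether an amine or a carboxylic acid on this ring would shift the number remains open. Compound 2 differs from compound 1 in more than one place, so its gap cannot be traced to any single change.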